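Swapping the benzyl group: compound 1 to compound 4

A few compounds are considered here, and "the series" means these few. Any claim that something is new, unique, unknown or untested is made for them only; others in the source may bear on it.

In a physicochemical assay for solubility (a lower number here means a less soluble compound, a higher number a more soluble compound), compound 1 `O=C(O)c1ccc(C(=O)/C(=C\c2ccc(F)c([N+](=O)[O-])c2)SCc2ccc(Cl)cc2Cl)cc1` gives < 1000 ug/mL, which is a limit and not a number. Compound 2 `COC(=O)c1ccc(C(=O)/C(=C\c2ccc(F)c([N+](=O)[O-])c2)SCc2ccc(Br)cc2)cc1` gives < 1000 ug/mL, again a limit. Compound 3 `O=C(O)c1ccc(C(=O)/C(=C\c2ccc(F)c([N+](=O)[O-])c2)S(=O)(=O)Cc2ccc(Br)cc2)cc1` gives < 1000 ug/mL, also a limit. Compound 1 therefore has no numeric position in the series, and the whole set comes down to the limit of < 1000 ug/mL in this assay, at which 3 of the 3 values shown sit.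

The structural change leading to compound 4 `O=C(O)c1ccc(C(=O)/C(=C\c2ccc(F)c([N+](=O)[O-])c2)SCc2ccc(C(F)(F)F)cc2)cc1` is 4-(trifluoromethyl)phenyl in place of 2,4-dichlorophenyl on a saturated chain carbon bound to a sulfur. Cut one bond further out, this reads 2,4-dichlorobenzyl to 4-(trifluoromethyl)benzyl. Both groups hold one six-membered aromatic ring of carbon only and carry no net charge.

Among the measured compounds shown here, the only measured step that bears on this part of the molecule is a step that the two limits leave unreadable from compound 1 to compound 3, so no size can be carried over from it. The expectation rests on compound 1, whose value of < 1000 ug/mL is a limit. The data support no direction, and the expected size is a step that the limit leaves unreadable from compound 1 to compound 4. Another reported limit is the likeliest result in this assay. As a number, compound 4 is estimated at 200 ug/mL, with an expected range of 20 ug/mL to 1000 ug/mL.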

Compound 4, solubility: < 1000 ug/mL
Compound 4: only a limit was reported; the forecaster's own chance of this, stated with the estimate: 85%; the middle value does not contradict the limit.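

In this assay compound 4 gives < 1000 ug/mL, which is a limit and not a number. Compound 1 also has only a limit, so no step can be read from compound 1 to compound 4. The compounds shown leave open where any of them lies numerically, and whether changing the benzyl group moves the read-out at all: the limit of < 1000 ug/mL in this assay, at which 4 of the 4 values shown sit.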